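Aryl swap on the sulfonyl sulfur of compound 3

The source may report more compounds than this note shows. Statements on the series, on what has been measured and on what is new or still open speak of the compounds shown alone.

Measured so far in a functional assay on HL-60 cells (Homo sapiens) for cytotoxicity, read by MTT assay; a lower number here means a stronger inhibitor, a higher number a weaker inhibitor
- Compound 1 `Cc1ccccc1S(=O)(=O)NC(C1=CC(=O)c2c(O)ccc(O)c2C1=O)C(C)C` gives 190 nM
- Compound 2 `CC(=O)c1ccc(S(=O)(=O)NC(C2=CC(=O)c3c(O)ccc(O)c3C2=O)C(C)C)cc1` gives 110 nM
- Compound 3 `Cc1ccccc1S(=O)(=O)NC(C)C1=CC(=O)c2c(O)ccc(O)c2C1=O` gives 70 nM

Compound 3 (70 nM) lies within the scatter of compound 2 (110 nM). Its gap to compound 1 is beyond the scatter, though modest, with methyl in place of isopropyl on the chain: a 2.7-fold lower number from compound 1 to compound 3 (0.43 log units; beyond the scatter) in this series.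

Going by the values given here, compound 4 `CC(NS(=O)(=O)c1cccc(Br)c1)C1=CC(=O)c2c(O)ccc(O)c2C1=O` keeps the methyl chain of compound 3 and carries 3-bromophenyl in place of 2-methylphenyl on a sulfonyl sulfur as the only change. The chain step therefore does not bear on it directly. Among the compounds with values here, the one measured swap at this place is 4-acetylphenyl in place of 2-methylphenyl, made on the isopropyl chain: a 1.7-fold lower number from compound 1 to compound 2 (0.24 log units; within the scatter) and so within the scatter. Within the data shown here, that is a single example, and no measured compound carries bromine, so the basis is thin. No step beyond the scatter is expected in this assay and no firm direction can be given. The estimated step is a 1.1-fold higher number from compound 3 to compound 4 (0.06 log units; within the scatter) and it is expected to stay within the scatter. The estimated value for compound 4 is 80 nM (expected range 30 nM to 200 nM).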

Compound 4, half-maximal inhibitory concentration: 160 nM
Compound 4: the middle estimate sits 2.0-fold (0.30 log units) below what was measured; the measured number falls inside the stated range.
By their numbers in this assay, from the lowest: compounds 3, 2, 4 and 1 (each within the scatter of the next, the first and the last beyond it).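

Going by these compounds alone, on the methyl chain in this assay, the swap to 3-bromophenyl in place of 2-methylphenyl on a sulfonyl sulfur gives a 2.3-fold higher number from compound 3 to compound 4 (0.36 log units; beyond the scatter) and so provides the first aryl change at this place to go beyond the scatter, though only modestly. Within the data shown here, the one earlier swap here, a 1.7-fold lower number from compound 1 to compound 2 (0.24 log units; within the scatter) stayed within the scatter, but it was made on the isopropyl chain with 4-acetylphenyl as the entering group, so the two steps are not a like-for-like comparison. The leaving and entering groups match in heavy-atom count and in carrying no hydrogen-bond donors or acceptors, so these counts do not separate them, and no measurement at hand accounts for the step.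

The compounds shown leave open whether the step follows the bromine itself or the different placement of the substituent on the aryl ring, a question that 3-methylphenyl and 2-bromophenyl groups on the methyl chain would separate. They also leave open whether 3-bromophenyl gives a similar step on the isopropyl chain, and how an aryl group bearing an amine or a carboxylic acid would read in this assay.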